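Aryl swap on the five-membered ring arm, compound 3 to 4

A few compounds are considered here, and "the series" means these few. Any claim that something is new, unique, unknown or untested is made for them only; others in the source may bear on it.

Measured so far:
compound 1, `C#CCN(c1nc2ccc(F)cc2s1)c1nc2ccc(OC)cc2s1`, in a functional assay on U-937 cells (Homo sapiens) for antiproliferative activity, read by MTT assay (a higher number here means a weaker inhibitor, a lower number a stronger inhibitor), compound 1 gives 24900 nM
compound 2, `COc1ccc2nc(N(Cc3cc(-c4ccc(OC(F)(F)F)cc4)no3)c3nc4ccc(F)cc4s3)sc2c1`, in this assay compound 2 gives 23100 nM
compound 3, `COc1ccc2nc(N(Cc3cc(-c4cc(OC)c(OC)c(OC)c4)no3)c3nc4ccc(F)cc4s3)sc2c1`, in this assay compound 3 gives 44000 nM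

Compound 3 shows the highest of the three numbers, but its gaps to compound 1 and to compound 2 are both within the scatter, so the three cannot be put in order on these data.

Compound 4, `COc1ccc2nc(N(Cc3cc(-c4ccccc4F)no3)c3nc4ccc(F)cc4s3)sc2c1`, differs from compound 3 in one place: 2-fluorophenyl in place of 3,4,5-trimethoxyphenyl on an aromatic carbon. Within the data shown here, the one measured step that bears on this change is the aryl exchange at the same carbon, a 1.9-fold higher number from compound 2 to compound 3 (0.28 log units; within the scatter), which stayed within the scatter. Among the measured compounds shown here, no other step touches this position. For the measured compounds named here, the series so far gives no sign that changing the aryl group on this carbon moves this assay beyond the scatter, and the two aryl-bearing compounds sit close to compound 1 as well.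

For compound 4 the expectation is therefore no step beyond the scatter, with a slight lean toward a lower number. Compound 4 is estimated at 30000 nM, range 12000 nM to 80000 nM, which means an expected step of a 1.5-fold lower number from compound 3 to compound 4 (0.17 log units; within the scatter).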

Compound 4, half-maximal inhibitory concentration: 29500 nM
Compound 4: the middle estimate sits 1.0-fold (0.01 log units) above what was measured; the range from low to high includes it.
By their numbers in this assay, from the lowest: compounds 2, 1, 4 and 3 (each within the scatter of the next).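

In this assay the exchange of 3,4,5-trimethoxyphenyl for 2-fluorophenyl on the aromatic carbon next to the ring nitrogen gives a 1.5-fold lower number from compound 3 to compound 4 (0.17 log units; within the scatter) and the exchange of 4-(trifluoromethoxy)phenyl for 2-fluorophenyl gives a 1.3-fold higher number from compound 2 to compound 4 (0.11 log units; within the scatter) as the second reading at this position. Even a change from a group with 12 heavy atoms and 3 hydrogen-bond acceptors to one with 7 heavy atoms and 0 hydrogen-bond acceptors therefore produces no step beyond the scatter, so compounds 2, 3 and 4 cannot be ordered and the earlier single step at this carbon now has two more beside it. No measurement at hand bears on the reason for these small steps.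

Open, going by these compounds, is whether a carboxylic acid or an amine on this aryl ring, or a longer chain in its place, would move the number in this assay beyond the scatter. Also open, on these data alone, is what an amine in place of the fluorine or the methoxy group on the shared core would do, since compounds 2, 3 and 4 all carry both.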